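From Methyl to Bromo on a Shared Core

The compounds below may be only part of what the source reports. "The series", "measured", "known", "first", "only" and "open" are said of these compounds alone.

In a functional assay on MDA-MB-231 cells (Homo sapiens) for cytotoxicity, read by MTT assay, with a stated time of 96 h (a higher number here means a weaker inhibitor, a lower number a stronger inhibitor), compound 1 `N=C(N)c1ccc(-c2ccc(-c3ccc([N+](=O)[O-])cc3)o2)cc1` gives 3100 nM while compound 2 `Cc1ccc(-c2ccc(-c3ccc(C(=N)N)cc3)o2)cc1` gives 3400 nM as its value. Among the measured compounds shown here, these are the only two numbers measured so far, and they lie within the scatter of each other, so compound 2 stands level with compound 1.

Compound 3 `N=C(N)c1ccc(-c2ccc(-c3ccc(Br)cc3)o2)cc1` has not yet been measured. Its difference from compound 2 is bromo in place of methyl on an aromatic carbon in one place, bromo in place of methyl on an aromatic carbon.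

For the measured compounds named here, the one measured step that bears on this change, a 1.1-fold higher number from compound 1 to compound 2 (0.04 log units; within the scatter) with methyl in place of nitro on an aromatic carbon, lies within the scatter. On that evidence, no step beyond the scatter is expected in this assay for the new change. Going by the values given here, no measured compound carries bromo, however, so this single step offers thin support and the range must stay wide. The expected size is an estimated 1.1-fold lower number from compound 2 to compound 3 (0.05 log units; within the scatter) with no firm direction. Compound 3 is estimated at 3000 nM with an expected range from 1200 nM to 6500 nM around it.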

Compound 3, half-maximal inhibitory concentration: 2700 nM
The estimate for compound 3 lay 1.1-fold (0.05 log units) above the measured number; low and high end bracket the measured number.
By their numbers in this assay, from the lowest: compounds 3, 1 and 2 (each within the scatter of the next).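

Bromo gives this position a third group, and in this assay the 4-methylphenyl to 4-bromophenyl change is a 1.3-fold lower number from compound 2 to compound 3 (0.10 log units; within the scatter) on the shared core, while the exchange of nitro for bromo at the same aromatic carbon is a 1.1-fold lower number from compound 1 to compound 3 (0.06 log units; within the scatter) in the same read-out. Where the earlier pair tested only one exchange, para to a large group, the three compounds now give three exchanges among nitro, methyl and bromo, and all of them stay within the scatter, so compounds 1, 2 and 3 stand level and none can be ranked above another. No accompanying measurement speaks to why these three groups read alike, and the numbers alone give no account of it.

Going by these compounds, what remains open is whether this level reading holds for a group of another kind at the same carbon, such as an amine, a carboxylic acid or a longer chain. The three compounds also say nothing about a change elsewhere on the shared core, since all of them differ only at this one position.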